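The source may report more compounds than this note shows. Statements on the series, on what has been measured and on what is new or still open speak of the compounds shown alone.

Measured in a functional assay on A549 cells (Homo sapiens) for cytotoxicity, read by MTT assay, with a stated time of 48 h; a higher number here means a weaker inhibitor, a lower number a stronger inhibitor:
- Compound 1 `COc1ccc(/C=C/c2cc(OC)c(OC)c(OC)c2-c2ccc(OC)cc2)cc1`: 35000 nM
- Compound 2 `COc1ccc(/C=C/c2cc(OC)c(OC)c(OC)c2-c2ccc3ccccc3c2)cc1`: 14000 nM

Of these two numbers, compound 2 holds the lower, at 14000 nM, so it is the stronger inhibitor of the pair in this assay. Compound 3 `COc1ccc(/C=C/c2cc(OC)c(OC)c(OC)c2-c2ccc(OC)c(OC)c2)cc1` keeps the shared core but carries 3,4-dimethoxyphenyl in place of naphthalen-2-yl on an aromatic carbon. Going by the values given here, one measured step bears on this change: a 2.5-fold lower number from compound 1 to compound 2 (0.40 log units; beyond the scatter), where naphthalen-2-yl replaced 4-methoxyphenyl at the same place. That step is modest, though beyond the scatter. Compound 3 gives up naphthalen-2-yl for a methoxy-bearing phenyl group again, so a move back toward a higher number, of similar modest size, seems likely. The expected change is a 2.0-fold higher number from compound 2 to compound 3 (0.30 log units; within the scatter). For compound 3 the estimated value is 28000 nM, with an expected range from 12000 nM to 60000 nM.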

Compound 3, half-maximal inhibitory concentration: 28000 nM
The estimate for compound 3 equals the measured number at the digits printed; measured number inside the range.
By their numbers in this assay, from the lowest: compounds 2, 3 and 1 (each within the scatter of the next, the first and the last beyond it).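

In this assay, 3,4-dimethoxyphenyl in place of naphthalen-2-yl gives a 2.0-fold higher number from compound 2 to compound 3 (0.30 log units; within the scatter), so this swap on the aromatic carbon does not clearly separate the two groups. Methoxy in place of hydrogen on the phenyl group gives a 1.3-fold lower number from compound 1 to compound 3 (0.10 log units; within the scatter), so this added methoxy also has no effect that can be told from the scatter, and the only step here beyond it remains a 2.5-fold lower number from compound 1 to compound 2 (0.40 log units; beyond the scatter). Compound 3 thus lies within the scatter of both neighbours, and nothing measured on these compounds explains the numbers.

At this place the compounds shown carry only methoxy-bearing phenyl groups and naphthalen-2-yl. As far as these compounds go, how a hydroxy group, an amine or a carboxylic acid on that phenyl group would read remains open.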